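Swapping a fluoro for methoxy on the aryl ring

The compounds below may be only part of what the source reports. "The series", "measured", "known", "first", "only" and "open" are said of these compounds alone.

Of the compounds shown here, three sharing one core have so far been tested in an ADME assay on Huh7.5.1 cells (Homo sapiens) for cytotoxicity, read by ATP content, with a stated time of 48 h; a higher number here means that more compound is tolerated, a lower number that less compound is tolerated. Compound 1, `Cc1oc(-c2c(F)cccc2F)nc1CN1CCC(C(=O)NCCCN2C[C@H](C)C[C@H](C)C2)CC1`, gives 32700 nM, the highest number of the three. Compound 2, `CC[C@@H]1C[C@H](CC)CN(CCCNC(=O)C2CCN(Cc3nc(-c4c(F)cccc4F)oc3C)CC2)C1`, gives 12600 nM, and compound 3, `Cc1ccccc1-c1nc(CN2CCC(C(=O)NCCCN3CC4CCCC(C4)C3)CC2)c(C)o1`, gives 10900 nM. Compound 3 differs from compound 1 at two places, so its value shows only that less of it is tolerated. Among the compounds with values here, the one single-point step is a 2.6-fold lower number from compound 1 to compound 2 (0.41 log units; beyond the scatter), a change at the far end of the molecule from the aromatic ring.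

Compound 4, `COc1cccc(F)c1-c1nc(CN2CCC(C(=O)NCCCN3C[C@H](C)C[C@H](C)C3)CC2)c(C)o1`, is the new compound: methoxy in place of fluoro on an aromatic carbon. Within the data shown here, no measured pair shows this kind of change on the aromatic ring, so nothing among the known numbers speaks to it directly; the step from compound 1 to compound 2 shows only that a small change elsewhere can move the number beyond the scatter. Among the measured compounds shown here, with no direct precedent, the expectation for compound 4 in this assay is a number close to that of compound 1, with a step of a 1.3-fold lower number from compound 1 to compound 4 (0.12 log units; within the scatter) expected to stay within the scatter. Compound 4 is therefore estimated at 25000 nM, with a range from 10000 nM to 60000 nM.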

Compound 4, half-maximal cytotoxic concentration: 37000 nM
Compound 4: the middle estimate sits 1.5-fold (0.17 log units) below what was measured, and the stated range covers the measured number.
By their numbers in this assay, from the lowest: compounds 3 and 2 (each within the scatter of the next); then compounds 1 and 4 (each within the scatter of the next).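

In this assay, the change from 2,6-difluorophenyl to 2-fluoro-6-methoxyphenyl gives a step that can be read directly (a 1.1-fold higher number from compound 1 to compound 4 (0.05 log units; within the scatter)), so compound 1 and compound 4 cannot be told apart here. Within the data shown here, this is the first measured change on the aromatic ring, and it shows that this carbon, ortho to a large group, accepts methoxy in place of fluoro with no change beyond the scatter, even though methoxy adds an oxygen and a hydrogen-bond acceptor. The change at the far end of the molecule, 3,5-diethylpiperidin-1-yl in place of 3,5-dimethylpiperidin-1-yl, behaves differently, with a step beyond the scatter (a 2.6-fold lower number from compound 1 to compound 2 (0.41 log units; beyond the scatter)), and no measurement offered here explains why either change has the outcome it does.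

On these data alone, whether this carbon would tolerate a larger or quite different group, such as an ethoxy group, a hydroxyl or an amine, stays open, since a single swap says little about the range of groups it can hold. Also open, as far as these compounds go, is what happens when the remaining fluoro group is replaced, for example by a second methoxy group. The compounds shown keep it in place whenever methoxy is present.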